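Replacing methoxy with chloro on compound 2

A few compounds are considered here, and "the series" means these few. Any claim that something is new, unique, unknown or untested is made for them only; others in the source may bear on it.

In an ADME assay on Vero cells (Chlorocebus sabaeus) for cytotoxicity, read by MTT assay, with a stated time of 72 h (on this read-out higher numbers stand for an effect only at larger amounts of compound and lower numbers for an effect already at smaller amounts), compound 2 `COc1cccc(C(=O)Nc2nc(-c3ccccn3)cs2)c1` gives 2800 nM, within the scatter of compound 1 `O=C(Nc1nc(-c2ccccn2)cs1)c1ccc(OCc2ccccc2)cc1` at 2300 nM, whereas compound 3 `CC(=O)c1ccc(C(=O)Nc2nc(-c3ccccn3)cs2)cc1` gives 10500 nM. Compound 4 `O=C(Nc1nc(-c2ccccn2)cs1)c1cccc(Cl)c1` differs from compound 2 in one place, with chloro in place of methoxy on an aromatic carbon. Among the measured compounds shown here, only one measured step bears on this change, and only indirectly: a 4.6-fold higher number from compound 1 to compound 3 (0.66 log units; beyond the scatter), a modest step with acetyl in place of benzyloxy on an aromatic carbon. It involves other groups, so it offers no direction here, and no change beyond the scatter is expected in this assay. The estimated step is a 1.1-fold lower number from compound 2 to compound 4 (0.03 log units; within the scatter). Compound 4 is estimated at 2600 nM, with an expected range from 1200 nM to 6000 nM.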

Compound 4, half-maximal effective concentration: 7000 nM
For compound 4 the middle estimate is 2.7-fold (0.43 log units) below the measured one; measured number outside the range, above it.
By their numbers in this assay, from the lowest: compounds 1 and 2 (each within the scatter of the next); then compounds 4 and 3 (each within the scatter of the next).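

Chloro in place of methoxy on this aromatic carbon, meta to a large group, is not a neutral exchange in this assay as it gives a 2.5-fold higher number from compound 2 to compound 4 (0.40 log units; beyond the scatter) in a modest step. Among the compounds shown here, this is the only direct reading at this position, and here the group with one hydrogen-bond acceptor gives way to one with none as the number rises. No measured property is available to explain the step. The compounds shown leave open how a fluoro group, a hydroxyl group or an amine on this same carbon would compare with methoxy and chloro. As far as these compounds go, whether the exchange gives a similar step elsewhere on this ring also stays open.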